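Adding a fluoro to compound 2

The source may hold more compounds than are shown below. What is called first, only, known or untested is meant among the compounds shown, and "the series" means these compounds.

Measured in a functional assay on A549 cells (Homo sapiens) for cytotoxicity, read by MTT assay, with a stated time of 48 h; a lower number here means a stronger inhibitor, a higher number a weaker inhibitor:
Compound 1 `O=C(/C=C/c1cccc(F)c1)Nc1ccc(CC2=CC(=O)OC2)cc1`: > 50000 nM
Compound 2 `C=C1OC(=O)C=C1Cc1ccc(NC(=O)/C=C/c2ccccc2)cc1`: 14800 nM
Compound 3 `C=C1OC(=O)C=C1Cc1ccc(NC(=O)c2ccccc2)cc1`: 49800 nM

Compound 1 gives > 50000 nM, which is a limit of the assay and not a number. That leaves two true numbers, and compound 2 holds the lower, at 14800 nM. The next structure, compound 4 `C=C1OC(=O)C=C1Cc1ccc(NC(=O)/C=C/c2cccc(F)c2)cc1`, differs from compound 2 in one place: fluoro in place of hydrogen on an aromatic carbon. In short, phenyl becomes 3-fluorophenyl.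

Among the measured compounds shown here, no measured step makes this exact swap. The nearest evidence in this assay is a 3.4-fold higher number from compound 2 to compound 3 (0.53 log units; beyond the scatter), a modest step in which phenyl replaces 2-phenylethenyl on a carbonyl carbon. That change alters the whole group on the carbonyl, whereas here a single hydrogen leaves. Compound 1 also carries a 3-fluorophenyl group, but its core differs and its limit gives no step size. A smaller step than the measured one is therefore expected, probably within the scatter and with no clear direction. The estimated change is a 1.1-fold lower number from compound 2 to compound 4 (0.06 log units; within the scatter). For compound 4, the expected value is 13000 nM, with an estimated range of 6000 nM to 30000 nM.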

Compound 4, half-maximal inhibitory concentration: 35200 nM
Compound 4: the middle estimate sits 2.7-fold (0.43 log units) below what was measured; measured number outside the range, above it.
By their numbers in this assay, from the lowest: compound 2; then compounds 4 and 3 (each within the scatter of the next). At a limit, above all of these: compound 1.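

In this assay, among the compounds shown here, the only earlier step replaced the whole group on the carbonyl, whereas here one atom on the aromatic ring is enough to change the result: a 2.4-fold higher number from compound 2 to compound 4 (0.38 log units; beyond the scatter). So this ring position is not indifferent to substitution, and for the one group tried, fluoro in place of hydrogen gives a weaker inhibitor than compound 2. Compound 1 stands at a limit of the assay, > 50000 nM, so the comparison yields only an at least 1.4-fold lower number from compound 1 to compound 4 (0.15 log units; that floor lies within the scatter), which establishes no real difference between the two five-membered rings.

Whether the loss belongs to fluoro itself or to any group at this place remains open, as the compounds shown carry no chloro, methoxy or amine on this ring. They also do not show why the fluoro raises the number.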